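From an imidazolyl sulfonamide to a bromophenyl analogue

The compounds below may be only part of what the source reports. "The series", "measured", "known", "first", "only" and "open" are said of these compounds alone.

The three measured compounds share a core in which a sulfonyl sulfur is joined to a sulfonamide nitrogen in a ring. Compound 1 `Cc1cccc(S(=O)(=O)N2CCC(N3CCC(C)CC3)CC2)c1` carries a 3-methylphenyl on that sulfur, compound 2 `CC1CCN(C2CCN(S(=O)(=O)c3ccccc3-c3ccc(C(F)(F)F)cc3)CC2)CC1` carries a bulkier substituent there, and compound 3 `CC1CCN(C2CCN(S(=O)(=O)c3nccn3C)CC2)CC1` carries a 1-methyl-1H-imidazol-2-yl.

In an ADME assay on HCT-116 cells (Homo sapiens) for cytotoxicity, read by CellTiter-Glo, with a stated time of 72 h (on this read-out lower numbers stand for stronger inhibition and higher numbers for weaker inhibition), compound 1 returns only a limit, > 5000 nM. Compound 2 likewise gives only a limit in this assay, > 5000 nM. Compound 3 also gives only a limit, > 10000 nM. Compound 3 thus stands at the limit of > 10000 nM in this assay, at which 1 of the 3 values shown sits. The two other compounds sit at the limit of > 5000 nM in this assay, at which 2 of the 3 values shown sit. Within the data shown here, the single measured step, a step that the two limits leave unreadable from compound 1 to compound 3, is therefore unreadable in size and direction.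

Compound 4 `CC1CCN(C2CCN(S(=O)(=O)c3ccccc3Br)CC2)CC1` differs from compound 3 by 2-bromophenyl in place of 1-methyl-1H-imidazol-2-yl on a sulfonyl sulfur. Among the measured compounds shown here, the only step that bears on this exchange is the unreadable one just named, and the two compounds that carry a carbon-only aromatic ring on the sulfonyl sulfur, compound 1 and compound 2, both show limits. No step beyond the scatter is therefore expected in this assay. Compound 4 is expected at 10000 nM, in the range 4000 nM to 30000 nM, most likely again reported as a limit. The estimated step of a number no higher from compound 3 to compound 4 (the limit leaves the size open) is expected to lie within the scatter.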

Compound 4, half-maximal inhibitory concentration: > 5000 nM
Compound 4: a limit, no number; the forecaster's own chance of this, stated with the estimate: 85%; the middle value is on the limit's open side.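

Compound 4 returns only a limit in this assay, so its steps from compound 1, compound 2 and compound 3 cannot be read in size or direction. All four compounds return limits, and they leave open whether any group on the sulfonyl sulfur gives a measurable value in this assay.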